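A few compounds are considered here, and "the series" means these few. Any claim that something is new, unique, unknown or untested is made for them only; others in the source may bear on it.

Working notes on the series. Compound 3 `COc1ccccc1-n1nncc1CN1C(=O)C2(C(C#N)=C(N)Oc3c(N)cc4nc5ccccc5nc4c32)c2ccccc21` carries a 2-methoxyphenyl on an aromatic nitrogen of the shared core. In a functional assay on MCF7 cells (Homo sapiens) for antiproliferative activity, read by MTT assay, with a stated time of 48 h (a lower number here means a stronger inhibitor, a higher number a weaker inhibitor), compound 3 gives 28900 nM, the only result in the set that is a number rather than a limit. Compound 1 `N#CC1=C(N)Oc2c(c3nc4ccccc4nc3c3ccccc23)C12C(=O)N(Cc1cnnn1-c1cccc(Br)c1)c1ccccc12` carries a 3-bromophenyl on that nitrogen. In this assay compound 1 returns only a limit, > 50000 nM. Compound 2 `N#CC1=C(N)Oc2c(c3nc4ccccc4nc3c3ccccc23)C12C(=O)N(Cc1cnnn1-c1ccc(N)cc1)c1ccccc12` carries a 4-aminophenyl there. In this assay compound 2 likewise returns only a limit, > 50000 nM. The step that the two limits leave unreadable from compound 1 to compound 2 thus has no readable size, and the limit of > 50000 nM in this assay, at which 2 of the 3 values shown sit, marks where two of the three results rest. Compound 4 `COc1cc(-n2nncc2CN2C(=O)C3(C(C#N)=C(N)Oc4c(N)cc5nc6ccccc6nc5c43)c3ccccc32)c(OC)cc1Cl` differs from compound 3 by 4-chloro-2,5-dimethoxyphenyl in place of 2-methoxyphenyl on an aromatic nitrogen. Among the measured compounds shown here, no measured step of readable size alters the group on this aromatic nitrogen, so nothing in the set points to a direction for the change. Compound 4 is therefore expected near 30000 nM, within 10000 nM to 90000 nM, with a real chance that this assay reports only a limit. The step of a 1.0-fold higher number from compound 3 to compound 4 (0.02 log units; within the scatter) is estimated as no larger than the scatter, in no settled direction.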

Compound 4, half-maximal inhibitory concentration: > 50000 nM
Compound 4 was reported as a limit; the forecaster's own chance of this, stated with the estimate: 40%; at least 1.6-fold (0.22 log units) between middle value and limit.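

Among the compounds shown here, compound 4 gives the first step at this aromatic nitrogen that starts from a number: in this assay the change is an at least 1.7-fold higher number from compound 3 to compound 4 (0.23 log units; that floor lies within the scatter). The result for compound 4 is a limit, so this step sets only a floor, and that floor does not show a change beyond the scatter. For the compounds shown here, with 4-chloro-2,5-dimethoxyphenyl in place of 2-methoxyphenyl, compound 3 remains the only compound with a number, and the results gather further at one limit: the limit of > 50000 nM in this assay, at which 3 of the 4 values shown sit.

The chlorine and the extra methoxy enter together in compound 4, so the step cannot be assigned to either one alone. As far as these compounds go, how a plain phenyl, a 2-hydroxyphenyl or a 2-chlorophenyl on this nitrogen would read in this assay remains open.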